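Fluoro on the second phenyl: compound 3 to compound 4

This account rests on a few compounds, and the source may have more. Where it says the series, first, only, none or still open, it means among the compounds named here.

Compound 3 `CC(=O)c1cc(-c2ccccc2)cc2cc(-c3ccc(F)cc3)[nH]c12` stands highest of the three numbers in a functional assay on HeLa cells (Homo sapiens) for cytotoxicity, read by MTT assay, with a stated time of 2 days, tested at 10 uM; a higher number here means a weaker effect of the compound at the concentration tested, a lower number a stronger effect: compound 3 gives 76.9%, against compound 1 `CC(=O)c1cc(-c2ccccc2)cc2cc(-c3ccccc3)[nH]c12` with 60.9% and compound 2 `CC(=O)c1cc(-c2ccc(F)cc2)cc2cc(-c3ccccc3)[nH]c12` with 55.7%. Compound 4 `CC(=O)c1cc(-c2ccc(F)cc2)cc2cc(-c3ccc(F)cc3)[nH]c12` differs from compound 3 by fluoro in place of hydrogen on an aromatic carbon. The same change on the other phenyl gave a number 5.2 percentage points lower from compound 1 to compound 2 (within the scatter); the change that produced compound 3 gave a number 16 percentage points higher from compound 1 to compound 3 (beyond the scatter). Only the first of these bears directly on the step to compound 4, and it stayed within the scatter, so no step beyond the scatter is expected. The expected step is a number 4.9 percentage points lower from compound 3 to compound 4 (within the scatter). For compound 4 the estimated value in this assay is 72%, within a range from 58% to 86%.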

Compound 4, a percentage reported as activity, at one concentration (the size of the read-out at that concentration, not a potency): 47.4%
For compound 4 the middle estimate is 24.6 percentage points above the measured one; the measured number lies below the stated range.
By their numbers in this assay, from the lowest: compounds 4, 2 and 1 (each within the scatter of the next, the first and the last beyond it); then compound 3.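

Phenyl to 4-fluorophenyl at this position gives a number 29.5 percentage points lower from compound 3 to compound 4 (beyond the scatter) in this assay, so the size of the step depends on whether the other phenyl carries fluoro: the same change on two cores in this assay, a number 5.2 percentage points lower (within the scatter) from compound 1 to compound 2 and a number 29.5 percentage points lower (beyond the scatter) from compound 3 to compound 4, 24.3 percentage points apart, beyond the scatter of two such steps

Read from the other phenyl, the same change gives a number 8.3 percentage points lower from compound 2 to compound 4 (within the scatter), so the two fluoro changes do not simply add: the same change on two cores in this assay, a number 16 percentage points higher (beyond the scatter) from compound 1 to compound 3 and a number 8.3 percentage points lower (within the scatter) from compound 2 to compound 4, 24.3 percentage points apart, beyond the scatter of two such steps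

From the compounds shown here alone, whether this dependence is particular to fluoro stays open. Chloro, methoxy or an amine in place of either fluoro would show whether it extends to other groups.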